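Butyl in place of benzoyl: compound 2 to compound 4

The compounds below may be only part of what the source reports. "The series", "measured", "known", "first", "only" and "open" are said of these compounds alone.

Of the compounds shown here, three have been read in a functional assay on 4T1 cells (Mus musculus) for antiproliferative activity, read by MTT assay, with a stated time of 48 h; a lower number here means a stronger inhibitor, a higher number a weaker inhibitor: compound 1 (`O=C1/C(=C/c2ccc(F)cc2)CN(C(=S)NC(=O)c2ccccc2)C/C1=C\c1ccc(F)cc1`), compound 2 (`Cc1ccccc1/C=C1\CN(C(=S)NC(=O)c2ccccc2)C/C(=C\c2ccccc2C)C1=O`) and compound 3 (`Cc1ccc(/C=C2\CN(C(=S)NC(=O)c3ccccc3)C/C(=C\c3ccc(C)cc3)C2=O)cc1`). Compound 1 gives < 10000 nM as a limit and not a number. Compound 3 gives < 10000 nM as a limit too. Compound 2 gives < 10000 nM as a limit also, so it has no exact position. For the measured compounds named here, the series so far reads as the limit of < 10000 nM in this assay, at which 3 of the 3 values shown sit, and allows no ranking of the three.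

Compound 4 (`CCCCNC(=S)N1C/C(=C\c2ccccc2C)C(=O)/C(=C/c2ccccc2C)C1`) carries butyl in place of benzoyl on an amide-type nitrogen. Going by the values given here, no measured step shows what this exchange does, so no shift beyond the scatter is expected in this assay and no direction is favoured. That expectation rests on compound 2 alone, at < 10000 nM as a limit. The estimated step (a step that the limit leaves unreadable from compound 2 to compound 4) is therefore loosely held. The expected value for compound 4 is 3000 nM (estimated range 500 nM to 10000 nM).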

Compound 4, half-maximal inhibitory concentration: < 10000 nM
Compound 4: no number, only a limit; the forecaster's own chance of this, stated with the estimate: 70%; the middle value is on the limit's open side.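

Compound 2 and compound 4 both give only a limit and not a number in this assay, so no step can be read between them: the limit of < 10000 nM in this assay, at which 4 of the 4 values shown sit.

The compounds shown leave open whether butyl in place of benzoyl shifts activity at all, and how compound 1, compound 2, compound 3 and compound 4 rank.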